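Removing the Acetyl Group from Compound 2

This account rests on a few compounds, and the source may have more. Where it says the series, first, only, none or still open, it means among the compounds named here.

Three amides sharing one core have been measured in an ADME assay on cells (Fibroblast, Homo sapiens) for antiproliferative activity, read by sulforhodamine B assay, with a stated time of 48 h; a higher number here means a weaker inhibitor, a lower number a stronger inhibitor. There, compound 1 `CCCCCCCCCCCCNC(=O)[C@@H]1CSC(c2ccc(NC(C)=O)cc2)N1` gives 3500 nM, compound 2 `CCCCCCCCCCCCCCCCNC(=O)[C@@H]1CSC(c2ccc(NC(C)=O)cc2)N1` gives 19100 nM and compound 3 `CCCCCCCCC/C=C\CCCCCCCNC(=O)[C@@H]1CSC(c2ccc(NC(C)=O)cc2)N1` gives 10600 nM. Compound 2 stands at the high end of these numbers, a place it shares with compound 3, as the gap of a 1.8-fold lower number from compound 2 to compound 3 (0.26 log units; within the scatter) shows.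

Compound 4 `CCCCCCCCCCCCCCCCNC(=O)[C@@H]1CSC(c2ccc(N)cc2)N1` differs from compound 2 by hydrogen in place of acetyl on a nitrogen on an aromatic ring, so that 4-acetamidophenyl becomes 4-aminophenyl. Among the compounds with values here, no measured step touches this place. All three changes lie in the chain, and they indicate only how far numbers move in this small set, with a 5.5-fold higher number from compound 1 to compound 2 (0.74 log units; beyond the scatter) and a 3.0-fold higher number from compound 1 to compound 3 (0.48 log units; beyond the scatter) as the two steps beyond the scatter. The data therefore give no firm direction for the new change. The expected result is a 1.3-fold lower number from compound 2 to compound 4 (0.10 log units; within the scatter), with no shift beyond the scatter anticipated. Compound 4 is estimated at 15000 nM, within an expected range of 5000 nM to 40000 nM.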

Compound 4, half-maximal inhibitory concentration: 7400 nM
Compound 4: middle estimate off by 2.0-fold (0.31 log units), on the high side; the measured number falls inside the stated range.
By their numbers in this assay, from the lowest: compound 1; then compounds 4, 3 and 2 (each within the scatter of the next, the first and the last beyond it).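

In this assay, within the data shown here, this is the first reading at this position: a 2.6-fold lower number from compound 2 to compound 4 (0.41 log units; beyond the scatter). The earlier steps shown here all lay in the chain and said nothing about the aromatic ring's substituent, whereas this one shows that hydrogen in place of acetyl on a nitrogen on an aromatic ring also moves the number beyond the scatter, here towards a stronger inhibitor. Nothing measured here accounts for this step.

The compounds shown leave open whether the change from 4-acetamidophenyl to 4-aminophenyl would move the number by a similar amount on the chains of compound 1 and compound 3. They also leave open whether a benzoyl group or a methyl group on this nitrogen would give a number closer to that of acetyl or to that of hydrogen.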